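A few compounds are considered here, and "the series" means these few. Any claim that something is new, unique, unknown or untested is made for them only; others in the source may bear on it.

Measured in an ADME assay on CCRF-CEM cells (Homo sapiens) for cytotoxicity, with a stated time of 72 h; on this read-out lower numbers stand for stronger inhibition and higher numbers for weaker inhibition:
Compound 1 `Clc1ccc(Cc2nn3c(Br)c(-c4ccc(Cl)cc4)nc3s2)cc1` gives > 250000 nM, which is a limit of this assay rather than a number.
Compound 2 `Clc1ccc(Cc2nn3c(Br)c(-c4ccc(Br)cc4)nc3s2)cc1` gives 238000 nM.
Compound 3 `N#CSc1c(-c2ccc(Cl)cc2)nc2sc(Cc3ccc(Cl)cc3)nn12` gives 30000 nM.

Compound 4 `N#CSc1c(-c2ccc(Br)cc2)nc2sc(Cc3ccc(Cl)cc3)nn12` remains to be measured.

The change from compound 1 to compound 2 is bromo in place of chloro on an aromatic carbon. Its step is an at least 1.0-fold lower number from compound 1 to compound 2 (0.02 log units; that floor lies within the scatter). Compound 1 sits at the limit of > 250000 nM in this assay, at which 1 of the 3 values shown sits, so that step is only a floor. The change from compound 3 to compound 4 is bromo in place of chloro on an aromatic carbon, the same change at the same place, carried on a different core. The two cores differ by cyanosulfanyl in place of bromo on an aromatic carbon, and that step is an at least 8.3-fold lower number from compound 1 to compound 3 (0.92 log units; beyond the scatter).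

For compound 4 the halogen swap is expected to give a 1.1-fold lower number from compound 3 to compound 4 (0.03 log units; within the scatter), essentially flat, because the same change earlier gave only an at least 1.0-fold lower number from compound 1 to compound 2 (0.02 log units; that floor lies within the scatter). Compound 4 is therefore estimated at 28000 nM, probably between 12000 nM and 65000 nM.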

Compound 4, half-maximal inhibitory concentration: 61000 nM
Compound 4: the middle estimate sits 2.2-fold (0.34 log units) below what was measured; the measured number falls inside the stated range.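

In this assay, the halogen swap on the cyanosulfanyl core gives a 2.0-fold higher number from compound 3 to compound 4 (0.31 log units; beyond the scatter), and whether this matches the swap on the bromo core stays unsettled: the same change on two cores in this assay, an at least 1.0-fold lower number (0.02 log units; that floor lies within the scatter) from compound 1 to compound 2 and a 2.0-fold higher number (0.31 log units; beyond the scatter) from compound 3 to compound 4; the limit leaves it open whether they differ
Cyanosulfanyl in place of bromo gives a lower number on both halogen variants, with a 3.9-fold lower number from compound 2 to compound 4 (0.59 log units; beyond the scatter), but a difference in size between the two steps cannot be claimed: the same change on two cores in this assay, an at least 8.3-fold lower number (0.92 log units; beyond the scatter) from compound 1 to compound 3 and a 3.9-fold lower number (0.59 log units; beyond the scatter) from compound 2 to compound 4; the limit leaves it open whether they differ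
Compound 1 gives > 250000 nM, which is a limit and not a number.

The compounds shown carry only bromo or cyanosulfanyl at the one place and only chloro or bromo at the other. From the compounds shown here alone, whether an amine, a carboxylic acid or a longer chain at either place would keep numbers like those of compound 3 and compound 4 stays open.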